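Shortening the Chain of a Compound at the Assay Limit

The source may report more compounds than this note shows. Statements on the series, on what has been measured and on what is new or still open speak of the compounds shown alone.

Two compounds differing in double-bond geometry, compound 1 `COCCCCCCCCCCCCCCC/C=C1/CC(CO)(COC(=O)C(C)(C)C)OC1=O` and compound 2 `COCCCCCCCCCCCCCCC/C=C1\CC(CO)(COC(=O)C(C)(C)C)OC1=O`, were tested in a functional assay on NCI-H322 cells (Homo sapiens) for antiproliferative activity; on this read-out lower numbers stand for stronger inhibition of growth and higher numbers for weaker inhibition of growth. Compound 1 gives > 10 ug/mL, which is a limit. Compound 2 gives > 10 ug/mL, also a limit, so compound 2 has no exact number of its own. Compound 3 `COCCCCCCCCCCC/C=C1\CC(CO)(COC(=O)C(C)(C)C)OC1=O` keeps the double bond of compound 2 and changes only the chain: methoxy in place of 4-methoxybutyl on a saturated chain carbon, ten or more bonds along the chain from a double-bonded chain carbon. For the measured compounds named here, the one measured step, a step that the two limits leave unreadable from compound 1 to compound 2, concerns the double bond rather than the chain, and its size stays unknown due to the limit of > 10 ug/mL in this assay, at which 2 of the 2 values shown sit. Going by the values given here, no measured step therefore speaks to chain length, and no shift beyond the scatter is expected in this assay, in either direction. The expected step is a step that the limit leaves unreadable from compound 2 to compound 3. Compound 3 is estimated at 12 ug/mL, with an expected range from 5 ug/mL to 30 ug/mL. A report as a limit alone is the likeliest outcome.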

Compound 3, concentration for 50% growth inhibition: > 10 ug/mL
Compound 3: no number, only a limit (the forecaster's own chance of this, stated with the estimate: 70%); the middle value does not contradict the limit.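

No new step can be read between compound 2 and compound 3 in this assay, due to the following: the limit of > 10 ug/mL in this assay, at which 3 of the 3 values shown sit. The compounds shown leave open whether chain length or double-bond geometry affects growth inhibition at all, and how strongly compounds 1, 2 and 3 act on these cells.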